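The source may report more compounds than this note shows. Statements on the series, on what has been measured and on what is new or still open speak of the compounds shown alone.

Compound 1 `COc1cc(COc2ccc(C(=O)NN)cc2)cc(OC)c1OC` is the parent hydrazide; in a physicochemical assay, with a stated time of 30 min (a higher number here means a weaker inhibitor, a lower number a stronger inhibitor), compound 1 gives 264 ug/mL. Compound 2 `COc1cc(COc2ccc(C(=O)N/N=C/c3cc(Br)cc(Cl)c3O)cc2)cc(OC)c1OC` carries the 5-bromo-3-chloro-2-hydroxyphenyl group, and in this assay compound 2 reaches only a limit of the assay, > 100 ug/mL, so compound 2 sits at the limit of > 100 ug/mL in this assay, at which 1 of the 3 values shown sits, and has no number of its own. For that reason the step that the limit leaves unreadable from compound 1 to compound 2 cannot be read. Compound 3 `COc1cc(COc2ccc(C(=O)N/N=C/c3cc(C(C)(C)C)c(O)c(C(C)(C)C)c3)cc2)cc(OC)c1OC` gives 62 ug/mL in this assay. Compound 4 `COc1cc(/C=N/NC(=O)c2ccc(OCc3cc(OC)c(OC)c(OC)c3)cc2)cc(OC)c1OC` is not yet measured; it differs from compound 2 by 3,4,5-trimethoxyphenyl in place of 5-bromo-3-chloro-2-hydroxyphenyl on a carbon with a double bond to nitrogen. Among the compounds with values here, no measured step shows this swap, and compound 2 offers only a limit, so the values of compound 1 and compound 3 set the plausible range. Compound 4 is expected near 150 ug/mL, between 70 ug/mL and 400 ug/mL. The step that the limit leaves unreadable from compound 2 to compound 4 behind this estimate is expected to remain unreadable against any measured one.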

Compound 4, half-maximal inhibitory concentration: > 100 ug/mL
Compound 4 was reported as a limit; the forecaster's own chance of this, stated with the estimate: 55%; the middle value lies beyond the limit too.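

Compound 4 gives only a limit of the assay, > 100 ug/mL, in this assay. Compound 2 also sits at a limit, so the step between compound 2 and compound 4 cannot be read. The compounds shown leave open whether 3,4,5-trimethoxyphenyl or 5-bromo-3-chloro-2-hydroxyphenyl gives the stronger inhibitor.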